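Swapping a Phenoxy Group for a Lactam on a Fused Core

The source may report more compounds than this note shows. Statements on the series, on what has been measured and on what is new or still open speak of the compounds shown alone.

Measured compounds:
Compound 1 `Cn1cc(-c2cnc(NCc3c(F)ccc4c3CCO4)c3cn[nH]c(=O)c23)cn1` gives 1000 nM in a physicochemical assay for solubility, read by LC-MS, in phosphate buffer, with a stated time of 24 h, at pH 7.4; a lower number here means a less soluble compound, a higher number a more soluble compound.
Compound 2 `Fc1ccc2c(c1CNc1ncc(Oc3ccccc3)c3nncn13)CCO2` gives 8000 nM in this assay.
Compound 3 `Cc1ncccc1-c1cnc(NCc2c(F)ccc3c2CCO3)n2c(=O)[nH]nc12` reaches only < 2000 nM in this assay, which is a limit of the measurement and not a number.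

Among the two numbers shown, compound 2 stands highest, and compound 1 sits well below it, beyond the usual scatter. The result for compound 3 is one of the values sitting at the limit of < 2000 nM in this assay, at which 1 of the 3 values shown sits.

Compound 4 `O=C1CCCN1c1cnc(NCc2c(F)ccc3c2CCO3)n2cnnc12` differs from compound 2 in one place: 2-oxopyrrolidin-1-yl in place of phenoxy on an aromatic carbon. No step between measured compounds is shown, so the expectation rests on this change alone. A modest rise in solubility is expected, a 2.5-fold higher number from compound 2 to compound 4 (0.40 log units; beyond the scatter). Compound 4 is estimated at 20000 nM, between 5000 nM and 80000 nM.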

Compound 4, solubility: 640000 nM
Beside the measured number, compound 4's estimate is 32-fold (1.51 log units) below it, and the stated range ends below it.
By their numbers in this assay, from the lowest: compound 1; then compound 2; then compound 4.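

Among these compounds, on this aromatic carbon of the shared core, 2-oxopyrrolidin-1-yl in place of phenoxy gives an 80-fold higher number from compound 2 to compound 4 (1.90 log units; beyond the scatter) in this assay and is the first step between measured compounds here. It shows that exchanging this one group, with the rest of the molecule unchanged, can move the number by a large amount. Nothing measured here says why the number moved so far. From the compounds shown here alone, whether another group at this place, such as an amine or a carboxylic acid, would give a similar number remains open. Also open, going by these compounds, is whether 2-oxopyrrolidin-1-yl would have the same effect on a different core.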